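Pyrrolidin-1-yl to Piperidin-1-yl on Two Cores

A few compounds are considered here, and "the series" means these few. Any claim that something is new, unique, unknown or untested is made for them only; others in the source may bear on it.

Measured compounds, with their results in a functional assay on U-373MG ATCC cells (Homo sapiens) for cytotoxicity, read by MTT assay, with a stated time of 72 h; a higher number here means a weaker inhibitor, a lower number a stronger inhibitor:
- compound 1 `O=C(c1ccccc1)c1sc(N2CCCC2)nc1Cl`: 82000 nM
- compound 2 `O=C(c1ccccc1)c1sc(N2CCCCC2)nc1Cl`: 96000 nM
- compound 3 `COC(=O)c1sc2nc(N3CCCC3)sc2c1C`: 89000 nM

Compound 1 and compound 2 share a core and differ in one group, (piperidin-1-yl in place of pyrrolidin-1-yl on an aromatic carbon). That swap gave a 1.2-fold higher number from compound 1 to compound 2 (0.07 log units; within the scatter). Compound 3 has a different core; how the two cores differ is not broken down here. Compound 4 `COC(=O)c1sc2nc(N3CCCCC3)sc2c1C` is built from compound 3 by the same kind of change, (piperidin-1-yl in place of pyrrolidin-1-yl on an aromatic carbon). The surroundings are not identical, since in compound 1 the group sits two ring bonds from the ring atom that bears a chloro group and from the ring atom that bears a group of 8 heavy atoms, whereas in compound 3 it sits on a ring that is part of a fused or bridged system of two rings. The step from compound 3 to compound 4 is expected to be about as small, a 1.2-fold higher number from compound 3 to compound 4 (0.07 log units; within the scatter), because the same swap gave a 1.2-fold higher number from compound 1 to compound 2 (0.07 log units; within the scatter). Compound 4 is therefore estimated at 105000 nM in this assay, between 50000 nM and 220000 nM.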

Compound 4, half-maximal inhibitory concentration: > 100000 nM
Compound 4: only a limit was reported; the forecaster's own chance of this, stated with the estimate: 20%; the middle value lies beyond the limit too.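

In this assay, compound 4 gives > 100000 nM, which is a limit of the assay and not an exact number. Replacing pyrrolidin-1-yl with piperidin-1-yl on the aromatic carbon gave an at least 1.1-fold higher number from compound 3 to compound 4 (0.05 log units; that floor lies within the scatter), so the result is compatible with this change carrying over from one core to the other, but it does not prove that it does. Whether the change has the same size on both cores remains unsettled, as the two steps can be compared only this far: the same change on two cores in this assay, a 1.2-fold higher number (0.07 log units; within the scatter) from compound 1 to compound 2 and an at least 1.1-fold higher number (0.05 log units; that floor lies within the scatter) from compound 3 to compound 4; the limit leaves it open whether they differ.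

The compounds shown leave open how a morpholine ring or an open-chain diethylamino group would read at this place in this assay, and whether either would give a step beyond the scatter. They also leave open what a carboxylic acid in place of the methyl ester on the core of compound 3 would do to the number.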